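Series notes: aryl swap on the carbonyl, compound 1 to compound 4

A few compounds are considered here, and "the series" means these few. Any claim that something is new, unique, unknown or untested is made for them only; others in the source may bear on it.

Measured so far:
compound 1 `COc1cc(-c2cc(/C=C/C(=O)c3ccc(Cl)c(Cl)c3)[nH]n2)cc(OC)c1OC` gives > 100000 nM
compound 2 `COc1ccc(-c2cc(/C=C/C(=O)c3cc(OC)c(OC)c(OC)c3)[nH]n2)cc1OC` gives 4910 nM
compound 3 `COc1ccc(-c2cc(/C=C/C(=O)c3ccc(N)cc3)[nH]n2)cc1` gives 13100 nM

All readings come from a functional assay on NCI-H23 cells (Homo sapiens) for inhibition, read by sulforhodamine B assay, with a stated time of 48 h; a lower number here means a stronger inhibitor of growth, a higher number a weaker inhibitor of growth. For compound 1 the entry is a limit of the assay, not a number, as the limit of > 100000 nM in this assay, at which 1 of the 3 values shown sits, records. Going by the values given here, no pair of measured compounds differs in a single place, so no measured step is available to size the change.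

Compound 4 `COc1ccc(C(=O)/C=C/c2cc(-c3cc(OC)c(OC)c(OC)c3)n[nH]2)cc1OC` differs from compound 1 by 3,4-dimethoxyphenyl in place of 3,4-dichlorophenyl on a carbonyl carbon. Since compound 2, which carries the same 3,4-dimethoxyphenyl and trimethoxyphenyl groups, gives 4910 nM, a move beyond the scatter toward stronger growth inhibition is expected. The step of an at least 14-fold lower number from compound 1 to compound 4 (1.15 log units; beyond the scatter) is expected to leave the limit behind. Compound 4 is estimated at 7000 nM, with a likely range of 2000 nM to 40000 nM.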

Compound 4, concentration for total growth inhibition: 5240 nM
Estimate against measurement, compound 4: 1.3-fold (0.13 log units) above, within the range that was stated.
By their numbers in this assay, from the lowest: compounds 2 and 4 (each within the scatter of the next); then compound 3. At a limit, above all of these: compound 1.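

This gives the series its first one-place comparison: on the carbonyl carbon, 3,4-dimethoxyphenyl in place of 3,4-dichlorophenyl gives an at least 19-fold lower number from compound 1 to compound 4 (1.28 log units; beyond the scatter) in this assay. The aryl group at this position therefore has a large bearing on the reading. The entry for compound 1 is a limit, so the full size of the step stays unknown: the limit of > 100000 nM in this assay, at which 1 of the 4 values shown sits.

Going by these compounds, whether the step follows the loss of the chlorines or the arrival of the methoxy groups remains open. On these data alone, how a hydroxyl or a carboxylic acid on that phenyl ring would read is also open.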